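The source may hold more compounds than are shown below. What is called first, only, known or untested is meant among the compounds shown, and "the series" means these compounds.

Of the compounds shown here, two have been measured in a functional assay on K562 cells (Homo sapiens) for inhibition, read by fluorescence, with a stated time of 72 h; on this read-out lower numbers stand for stronger inhibition of growth and higher numbers for weaker inhibition of growth. Compound 1, `CC(C)c1nc(-c2ccccc2)cc2nn(-c3ccccc3)cc12`, gives 36800 nM in this assay. Among the measured compounds shown here, compound 2, `c1ccc(-c2cc3nn(-c4ccccc4)cc3cn2)cc1`, gives 3400 nM in this assay, the lowest of the two numbers; the only step, an 11-fold lower number from compound 1 to compound 2 (1.03 log units; beyond the scatter), comes from hydrogen in place of isopropyl on an aromatic carbon. Compound 3, `OCCc1cc2nn(-c3ccccc3)cc2cn1`, has not yet been measured. Its difference from compound 2 is 2-hydroxyethyl in place of phenyl on an aromatic carbon. For the measured compounds named here, that measured step concerns a different group at a different place on the shared core, so nothing measured so far speaks directly to the exchange of phenyl for 2-hydroxyethyl, and the expectation can rest only on the value of compound 2 itself. In this assay compound 3 is therefore expected to give roughly 8000 nM, a step of a 2.4-fold higher number from compound 2 to compound 3 (0.37 log units; beyond the scatter) from compound 2, with a wide range from 1500 nM to 40000 nM because the step of an 11-fold lower number from compound 1 to compound 2 (1.03 log units; beyond the scatter) shows how much a single change at one place can move the number.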

Compound 3, concentration for 50% growth inhibition: > 100000 nM
Compound 3: a limit, no number; the forecaster's own chance of this, stated with the estimate: 5%; at least 12-fold (1.09 log units) between middle value and limit.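

Until now, only the place that carries isopropyl in compound 1 had been varied. Among the compounds shown here, this change is the first at the aromatic carbon next to the ring nitrogen, and it shows that the number in this assay depends strongly on the group there: 2-hydroxyethyl in place of phenyl gives an at least 29-fold higher number from compound 2 to compound 3 (1.46 log units; beyond the scatter). Compound 3 stands at a limit of the assay, not at a number: the limit of > 100000 nM in this assay, at which 1 of the 3 values shown sits.

The change removes a ring and brings in a hydroxyl group in a single exchange, and the compounds shown do not tell which of the two matters. As far as these compounds go, a plain ethyl group, a longer chain ending in hydroxyl or a pyridine ring at this place would separate the two, and whether any group here gives a lower number than phenyl in compound 2 remains open.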